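From ethoxy to propoxy: one added methyl

A few compounds are considered here, and "the series" means these few. Any claim that something is new, unique, unknown or untested is made for them only; others in the source may bear on it.

Compound 1 `C/C(=N\OCCC(=O)O)c1ccc(Cl)cc1`: 80 mg/kg
Compound 2 `CCOC(=O)CO/N=C(\C)c1ccc(Cl)cc1`: 32 mg/kg

Both values come from a functional assay on the whole organism for inhibition, with Rattus norvegicus as the target, read by paw edema, with stated times of 1 h and 3 h; a lower number here means that less compound is needed, a higher number that more compound is needed for the effect. Compound 2 holds the lower of the two numbers. For the measured compounds named here, the single measured step is modest: a 2.5-fold lower number from compound 1 to compound 2 (0.40 log units; beyond the scatter). Compound 3 `CCCOC(=O)CO/N=C(\C)c1ccc(Cl)cc1` is still to be measured in this assay. Its structure differs from that of compound 2 by methyl in place of hydrogen on a saturated chain carbon, two bonds along the chain from an oxygen next to a carbonyl group, which turns ethoxy into propoxy. Going by the values given here, the measured step exchanges carboxymethyl for ethoxycarbonyl, so it bears on this change only loosely, and no measured pair shows ethyl going to propyl. A small change is therefore expected, with no shift beyond the scatter in either direction. The expected step is a 1.1-fold lower number from compound 2 to compound 3 (0.03 log units; within the scatter). Compound 3 is estimated at 30 mg/kg, with an expected range from 13 mg/kg to 70 mg/kg.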

Compound 3, dose for half-maximal effect: 14 mg/kg
Beside the measured number, compound 3's estimate is 2.1-fold (0.33 log units) above it, within the range that was stated.
By their numbers in this assay, from the lowest: compound 3; then compound 2; then compound 1.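

In this assay the added methyl that turns ethoxy into propoxy is not a silent change: it gives a 2.3-fold lower number from compound 2 to compound 3 (0.36 log units; beyond the scatter) and so moves the number on its own, at a saturated chain carbon two bonds along the chain from an oxygen next to a carbonyl group. Set against the carboxymethyl compound, the propoxycarbonyl group gives a 5.7-fold lower number from compound 1 to compound 3 (0.76 log units; beyond the scatter) and leaves compound 3 with the lowest number of the three. Nothing measured here speaks to what lies behind this step.

On these data alone, whether the number keeps falling with a butoxy group or a longer chain, or turns back, remains open. Also open, as far as these compounds go, is how a branched isopropoxy group or an amide in place of the ester would read in this assay on the same core.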